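A few compounds are considered here, and "the series" means these few. Any claim that something is new, unique, unknown or untested is made for them only; others in the source may bear on it.

Measured in a functional assay on U-373MG ATCC cells for inhibition, with U373 MG (Homo sapiens) as the target, read by MTT assay, with a stated time of 7 days; on this read-out higher numbers stand for weaker inhibition of growth and lower numbers for stronger inhibition of growth:
- Compound 1 `C#CC/N=N/Nc1[nH]cnc1C(N)=O`: 32000 nM
- Compound 2 `NC(=O)c1nc[nH]c1N/N=N/Cc1ccco1`: > 50000 nM (a limit, not a number)

Compound 2 gives no number, only a limit: the limit of > 50000 nM in this assay, at which 1 of the 2 values shown sits. Compound 3 `NC(=O)c1nc[nH]c1N/N=N/Cc1ccoc1` differs from it in one place: furan-3-yl in place of furan-2-yl on a saturated chain carbon bound to a double-bonded nitrogen. Among the compounds with values here, only one measured step bears on this change, an at least 1.5-fold higher number from compound 1 to compound 2 (0.19 log units; that floor lies within the scatter), where furan-2-yl replaced ethynyl at that same place. From the compounds shown here alone, its floor stays within the scatter and its full size is unknown, so no step beyond the scatter is expected in this assay for this swap of one furan for the other. The expected change is a number no higher from compound 2 to compound 3 (the limit leaves the size open). For compound 3 the estimate is 50000 nM, with an expected range of 25000 nM to 100000 nM.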

Compound 3, concentration for 50% growth inhibition: > 50000 nM
Compound 3: a limit, no number; the forecaster's own chance of this, stated with the estimate: 70%; the middle value sits exactly at the limit.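

In this assay, furan-3-yl in place of ethynyl at this place gives an at least 1.5-fold higher number from compound 1 to compound 3 (0.19 log units; that floor lies within the scatter), so this furan, like furan-2-yl, yields no number. The step between compound 2 and compound 3 cannot be read: both give only a limit. Moving the furan's point of attachment therefore brings no readable value, and the limit now holds most of the compounds shown: the limit of > 50000 nM in this assay, at which 2 of the 3 values shown sit.

From the compounds shown here alone, how far the true values of the two furan compounds lie past that limit stays open. So does whether an amine or a longer chain at this place would give a readable number.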